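A few compounds are considered here, and "the series" means these few. Any claim that something is new, unique, unknown or untested is made for them only; others in the source may bear on it.

Compound 1 `COc1ccc(/C=C/c2nc(NCCN(C(C)C)C(C)C)c3ccccc3n2)cc1OC` and compound 2 `COc1ccc(/C=C/c2nc(NCCN3CCCCC3)c3ccccc3n2)cc1OC` share one core and differ in a single spot: piperidin-1-yl in place of diisopropylamino on a saturated chain carbon, two bonds along the chain from a nitrogen on an aromatic ring. In a functional assay on PC-3 cells (Homo sapiens) for cytotoxicity, read by MTT assay, with stated times of 48 h and 4 h (on this read-out lower numbers stand for stronger inhibition and higher numbers for weaker inhibition), compound 1 gives 20300 nM, and compound 2 gives 78500 nM, a step of a 3.9-fold higher number from compound 1 to compound 2 (0.59 log units; beyond the scatter). Compound 3 `CC(C)N(CCNc1nc(/C=C/c2ccc([N+](=O)[O-])cc2)nc2ccc(Cl)cc12)C(C)C` rests on a different core; the difference between the two cores is not broken down here. In this assay compound 3 reaches only a limit of the assay, > 100000 nM. Compound 4 `O=[N+]([O-])c1ccc(/C=C/c2nc(NCCN3CCCCC3)c3cc(Cl)ccc3n2)cc1` has not yet been measured and differs from compound 3 by the same change: piperidin-1-yl in place of diisopropylamino on a saturated chain carbon, two bonds along the chain from a nitrogen on an aromatic ring. A step of about the same size is expected here, a step that the limit leaves unreadable from compound 3 to compound 4, because the measured step of a 3.9-fold higher number from compound 1 to compound 2 (0.59 log units; beyond the scatter) points that way and the starting point already sits at the limit of > 100000 nM in this assay, at which 1 of the 3 values shown sits. Compound 4 is therefore estimated at 300000 nM, most likely reported only as a limit.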

Compound 4, half-maximal inhibitory concentration: > 100000 nM
Compound 4: no number, only a limit; the forecaster's own chance of this, stated with the estimate: 85%; the middle value lies beyond the limit too.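

No step can be read from compound 3 to compound 4, because both compounds stand only as limits: the limit of > 100000 nM in this assay, at which 2 of the 4 values shown sit.

Going by these compounds, whether piperidin-1-yl in place of diisopropylamino changes the number on the core of compound 3 as it does on the core of compound 1 stays open.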